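Urea-Bearing Pyrrolidine Replaces Dipropylamino on the Shared Core

This account rests on a few compounds, and the source may have more. Where it says the series, first, only, none or still open, it means among the compounds named here.

Measured compounds:
compound 1, `CCCN(CCC)c1ccc2cc(NC(=O)CCc3ccc(C(F)(F)F)cc3)ccc2n1`, 490 nM
compound 2, `CCCc1cc(N(C)C)c2cc(NC(=O)CCc3ccc(C(F)(F)F)cc3)ccc2n1`, 12 nM

The two measured compounds share the amide-linked core carrying a trifluoromethyl group. In an assay on isolated protein for displacement of a labelled ligand from melanin-concentrating hormone receptor 1 (Homo sapiens) (on this read-out lower numbers stand for stronger inhibition and higher numbers for weaker inhibition), compound 1 gives 490 nM, the higher of the two numbers shown. Compound 2 gives 12 nM in this assay, a gap that lies beyond the scatter; compound 2 differs from compound 1 in more than one place, so no single change can be held responsible.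

Compound 3, `CNC(=O)NC1CCN(c2ccc3cc(NC(=O)CCc4ccc(C(F)(F)F)cc4)ccc3n2)C1`, has not yet been measured. It differs from compound 1 in one place: 3-((methylcarbamoyl)amino)pyrrolidin-1-yl in place of dipropylamino on an aromatic carbon. No comparable change is available among the measured compounds, so the direction cannot be read from them.

Compound 3 is expected to show a moderate step in this assay, a 3.3-fold lower number from compound 1 to compound 3 (0.51 log units; beyond the scatter), toward a lower number. The estimated value of compound 3 in this assay is 150 nM, with a range from 30 nM to 800 nM.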

Compound 3, half-maximal inhibitory concentration: 6 nM
Estimate against measurement, compound 3: 25-fold (1.40 log units) above, outside the stated range (below it).
By their numbers in this assay, from the lowest: compounds 3 and 2 (each within the scatter of the next); then compound 1.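

In this assay, among these compounds, the change gives an 82-fold lower number from compound 1 to compound 3 (1.91 log units; beyond the scatter), the first single-place step on the shared core, and it shows that the group on the aromatic carbon next to the ring nitrogen has a large bearing on the read-out. It also shows that this position accepts more than a plain dialkylamino group: 3-((methylcarbamoyl)amino)pyrrolidin-1-yl brings a five-membered non-aromatic ring, a double bond outside aromatic rings and 2 hydrogen-bond donors where dipropylamino has 0 hydrogen-bond donors, and the number falls rather than rises. No measurement at hand bears on why the step is this large, so the result records the size of the effect and gives no account of its origin.

The ring and the methylcarbamoyl-amino side chain enter together, so the compounds shown do not divide the step between them; unsubstituted pyrrolidin-1-yl or 3-aminopyrrolidin-1-yl in the same place would separate the two parts. Nor do they say whether the urea needs the ring, a question that an open-chain amine carrying the same urea on the shared core would address.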